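Ethoxycarbonyl to hydroxymethyl on a three-membered ring

The source may hold more compounds than are shown below. What is called first, only, known or untested is meant among the compounds shown, and "the series" means these compounds.

Measured so far in a functional assay on A549 cells (Homo sapiens) for cytotoxicity, read by MTT assay, with a stated time of 48 h (a lower number here means a stronger inhibitor, a higher number a weaker inhibitor), for two compounds:
Compound 1 `COc1cc([C@@H]2C[C@@]2(CO)C(=O)Nc2ccccc2)cc(OC)c1OC` gives 43200 nM
Compound 2 `CCOC(=O)[C@]1(C(=O)Nc2ccccc2)C[C@H]1c1cc(OC)c(OC)c(OC)c1` gives 37300 nM

Compound 2 stands level with compound 1. Their two numbers lie within the usual scatter of repeated measurements, so neither can be ranked over the other.

The next compound to be tested is compound 3 `COc1cc([C@@H]2C[C@]2(CO)C(=O)Nc2ccccc2)cc(OC)c1OC` and it differs from compound 2 in one place: hydroxymethyl in place of ethoxycarbonyl on a saturated ring carbon. Within the data shown here, no pair of measured compounds shows this change on its own, so there is no direct precedent for its size. The nearest evidence is indirect. Compound 1 carries a hydroxymethyl too and gives 43200 nM in this assay while compound 2, with ethoxycarbonyl, gives 37300 nM on the same scale.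

On that evidence, no change beyond the scatter is expected in this assay and no direction is favoured, so the estimate for a 1.1-fold higher number from compound 2 to compound 3 (0.03 log units; within the scatter) is a small one. For compound 3 the estimated value is 40000 nM with a range from 18000 nM to 90000 nM expected.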

Compound 3, half-maximal inhibitory concentration: 24100 nM
Beside the measured number, compound 3's estimate is 1.7-fold (0.22 log units) above it; low and high end bracket the measured number.
By their numbers in this assay, from the lowest: compounds 3, 2 and 1 (each within the scatter of the next).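

In this assay, among these compounds, the step of a 1.5-fold lower number from compound 2 to compound 3 (0.19 log units; within the scatter) gives the first direct reading of hydroxymethyl in place of ethoxycarbonyl on this saturated ring carbon, and it stays within the usual scatter. The smaller hydroxymethyl, with a hydrogen-bond donor that ethoxycarbonyl lacks, can therefore stand at this position with no readable shift in this assay, though one pair cannot show that this holds on other compounds. The step of a 1.8-fold lower number from compound 1 to compound 3 (0.25 log units; within the scatter) is also within the scatter, so swapping the drawn configuration at this stereocentre has no readable effect here, and this pair gives an unusually clean test of that single feature: the fact that compounds 1 and 3 differ only in the configuration as drawn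

Neither step moves the number beyond the scatter, so the compounds shown leave open whether anything at this ring carbon matters much for the cytotoxicity, for instance a carboxylic acid, an aminomethyl group or a longer chain such as a hydroxypropyl group. They also leave open what happens when the configuration at the other stereocentre changes, since only one of the two differs between the compounds that share the same atoms and bonds.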